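Swapping ethoxy for hydrogen on compound 3

The compounds below may be only part of what the source reports. "The series", "measured", "known", "first", "only" and "open" are said of these compounds alone.

Compound 1 `CCOC1C=C(CC[C@]2(C)[C@@H](C)CC[C@@]3(C)C(C(=O)O)=CC=C[C@@H]23)C(=O)O1`: > 40000 nM (a limit)
Compound 2 `CCOC1C=C(CC[C@]2(C)[C@@H](C)CC[C@@]3(C)C(C(=O)O)=CCC[C@@H]23)C(=O)O1`: > 40000 nM (a limit)
Compound 3 `C=C1CC[C@H](C)[C@@](C)(CCC2=CC(OCC)OC2=O)C/C=C\C=C/1C(=O)O`: > 40000 nM (a limit)

In a functional assay on MCF7 cells (Homo sapiens) for cytotoxicity, read by MTT assay, with a stated time of 24 h (a higher number here means a weaker inhibitor, a lower number a stronger inhibitor), compound 3 gives > 40000 nM as a limit and not a number. Going by the values given here, the series as a whole shows the limit of > 40000 nM in this assay, at which 3 of the 3 values shown sit, and offers no measured step to build on. Compound 4 `C=C1CC[C@H](C)[C@@](C)(CCC2=CCOC2=O)C/C=C\C=C/1C(=O)O` differs from compound 3 by a single change: hydrogen in place of ethoxy on a saturated ring carbon. No shift beyond the scatter is expected in this assay for this change. The expected step is a number no higher from compound 3 to compound 4 (the limit leaves the size open) and no direction is favoured. Compound 4 is estimated to give 40000 nM with an expected range from 15000 nM to 80000 nM. The outcome for compound 4 may prove to be only a limit.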

Compound 4, half-maximal inhibitory concentration: > 40000 nM
Compound 4 was reported as a limit (the forecaster's own chance of this, stated with the estimate: 70%); the middle value sits exactly at the limit.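

No step can be read from compound 3 to compound 4, because both are reported only as limits: the limit of > 40000 nM in this assay, at which 4 of the 4 values shown sit.

The compounds shown leave open how strongly any of them acts and whether swapping ethoxy for hydrogen changes that at all.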